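Changing the Aryl Group on the Ring Amine Nitrogen

A few compounds are considered here, and "the series" means these few. Any claim that something is new, unique, unknown or untested is made for them only; others in the source may bear on it.

In a functional assay on HL-60 cells (Homo sapiens) for inhibition, read by MTT assay, with a stated time of 72 h (on this read-out lower numbers stand for stronger inhibition and higher numbers for weaker inhibition), compound 2 `Cc1nc(-c2ccccc2)c(C(=O)N2CCN(c3cccc(C#N)c3)CC2)o1` gives 39.6 nM, the only numerical result in this small set. Compound 1 `Cc1ccc(N2CCN(C(=O)c3oc(C)nc3-c3ccccc3)CC2)cc1` reaches only a limit of this assay, > 1000 nM. Among the measured compounds shown here, the single measured step, an at least 25-fold lower number from compound 1 to compound 2 (1.40 log units; beyond the scatter), is the one comparison that bears on compound 3 `Cc1nc(-c2ccccc2)c(C(=O)N2CCN(c3ccc(C(F)(F)F)cc3)CC2)o1`, which differs from compound 2 by 4-(trifluoromethyl)phenyl in place of 3-cyanophenyl on an amine nitrogen in a ring. Because that step an at least 25-fold lower number from compound 1 to compound 2 (1.40 log units; beyond the scatter) was large, a large move in the opposite direction is expected for compound 3, namely a 13-fold higher number from compound 2 to compound 3 (1.10 log units; beyond the scatter). Compound 3 is therefore estimated at 500 nM, with a range from 100 nM to 3000 nM, and a real chance of only a limit being reported.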

Compound 3, half-maximal inhibitory concentration: > 1000 nM
Compound 3: only a limit was reported; the forecaster's own chance of this, stated with the estimate: 35%; middle value at least 2.0-fold (0.30 log units) from the limit.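

In this assay the change gives an at least 25-fold higher number from compound 2 to compound 3 (1.40 log units; beyond the scatter), so a second replacement of 3-cyanophenyl on this amine nitrogen, after 4-methylphenyl, also ends far weaker. Of the three aryl groups, only 3-cyanophenyl gives a numerical result here, while 4-methylphenyl and 4-(trifluoromethyl)phenyl do not. Compound 1 and compound 3 cannot be read against each other, as both stand at the same limit: the limit of > 1000 nM in this assay, at which 2 of the 3 values shown sit.

The compounds shown leave open whether the nitrile itself or its placement on the phenyl ring matters. A 4-cyanophenyl or 3-(trifluoromethyl)phenyl group would separate the two.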